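The source may hold more compounds than are shown below. What is called first, only, known or untested is meant among the compounds shown, and "the series" means these compounds.

Compound 1 `COc1cc(-c2nnc(SCc3ccccc3Br)o2)ccc1O` gives 17800 nM in a functional assay on cells (T-cell, Mus musculus, strain BALB/c) for inhibition, read by MTT assay, with stated times of 24 h and 72 h; on this read-out higher numbers stand for weaker inhibition and lower numbers for stronger inhibition. For the measured compounds named here, compound 2 `COc1cc(-c2nnc(SCc3ccc(Br)cc3)o2)ccc1O` gives 8830 nM in this assay; the single step between them is a 2.0-fold lower number from compound 1 to compound 2 (0.30 log units; within the scatter). Compound 2 thus holds the lower of the two numbers gathered so far, but its gap to compound 1 is within the scatter, so the two compounds cannot be ordered on this read-out.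

Compound 3 `COc1cc(-c2nnc(SCc3ccc(Br)cc3)o2)ccc1OCc1ccc(Br)cc1` has not been measured. It differs from compound 2 in one place: 4-bromobenzyl in place of hydrogen on an oxygen on an aromatic ring. Going by the values given here, the only measured step, a 2.0-fold lower number from compound 1 to compound 2 (0.30 log units; within the scatter), concerns the bromophenyl group alone and leaves the oxygen on the aromatic ring untouched, so no measured step bears on the present change. That step also did not leave the scatter, which gives no direction to read from. With nothing to go on beyond the value of compound 2, the expected step is a 1.0-fold higher number from compound 2 to compound 3 (0.01 log units; within the scatter), meaning no movement beyond the scatter, with a wide range on both sides. Compound 3 is accordingly estimated at 9000 nM in this assay, with a range of 2500 nM to 35000 nM.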

Compound 3, half-maximal inhibitory concentration: 17300 nM
For compound 3 the middle estimate is 1.9-fold (0.28 log units) below the measured one; the measured number falls inside the stated range.
By their numbers in this assay, from the lowest: compounds 2, 3 and 1 (each within the scatter of the next).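

The oxygen on the aromatic ring now has its first substitution in the series: in this assay, replacing hydroxy with (4-bromobenzyl)oxy gives a 2.0-fold higher number from compound 2 to compound 3 (0.29 log units; within the scatter). The free hydroxy is thus not shown to be needed on this read-out, as a group of 8 heavy atoms with one six-membered aromatic ring enters at this oxygen and the step stays within the scatter. No measurement at hand offers an explanation for this outcome.

Still open, on these data alone, is whether any group on this oxygen can carry the number beyond the scatter in either direction, whether a small one such as methyl, a longer chain, or a chain ending in an amine or a carboxylic acid. For the compounds shown here, also open is what part the bromine plays in the entering group, which a plain benzyl or a 4-fluorobenzyl on the same oxygen would address, and with only one substituted example at this position, no trend can yet be drawn for it.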